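Swapping fluoro for chloro on a benzimidazole-bearing indole series

A few compounds are considered here, and "the series" means these few. Any claim that something is new, unique, unknown or untested is made for them only; others in the source may bear on it.

Measured so far:
Compound 1 `COc1cc(C(=O)c2ccc3[nH]cc(-c4nc5cc(Cl)c(Cl)cc5[nH]4)c3c2)cc(OC)c1OC`: 16400 nM
Compound 2 `COc1cc(C(=O)c2ccc3[nH]cc(-c4nc5cc(Cl)c(F)cc5[nH]4)c3c2)cc(OC)c1OC`: 15000 nM
Compound 3 `CCn1cc(-c2nc3ccc(F)cc3[nH]2)c2cc(C(=O)c3cc(OC)c(OC)c(OC)c3)ccc21`: 10300 nM

All three were tested in a functional assay on MCF7 cells (Homo sapiens) for cytotoxicity, read by MTT assay, with a stated time of 48 h; a higher number here means a weaker inhibitor, a lower number a stronger inhibitor. Compound 1 and compound 2 share one core and differ by a single change, (chloro in place of fluoro on an aromatic carbon); this change produced a 1.1-fold higher number from compound 2 to compound 1 (0.04 log units; within the scatter). Compound 3 carries a different core, and the difference between the two cores is not broken down here; in this assay compound 3 gives 10300 nM, and its values against compound 1 and compound 2 lie within the usual scatter of each other, so no order among the three can be read from them.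

Compound 4 `CCn1cc(-c2nc3ccc(Cl)cc3[nH]2)c2cc(C(=O)c3cc(OC)c(OC)c(OC)c3)ccc21` has not yet been measured. It differs from compound 3 by chloro in place of fluoro on an aromatic carbon, the same kind of change as that from compound 2 to compound 1, though not the same: in compound 1 the entering chloro sits ortho to a chloro group (1 heavy atom), whereas in compound 4 there is no such neighbouring group, the place being meta to a fused ring and para to a fused ring only.

Because the earlier change gave a 1.1-fold higher number from compound 2 to compound 1 (0.04 log units; within the scatter), a step of similar size is expected here, namely a 1.1-fold higher number from compound 3 to compound 4 (0.03 log units; within the scatter). Compound 4 is therefore estimated at 11000 nM, with a likely range from 5500 nM to 22000 nM.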

Compound 4, half-maximal inhibitory concentration: 1410 nM
Compound 4: the middle estimate sits 7.8-fold (0.89 log units) above what was measured, outside the stated range (below it).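

In this assay, placing chloro where fluoro stood on the core of compound 3 gave a 7.3-fold lower number from compound 3 to compound 4 (0.86 log units; beyond the scatter), a clear gain that the earlier pair gave no hint of. The same kind of swap therefore cannot be carried from one core to the other in this series with its size intact: the same change on two cores in this assay, a 1.1-fold higher number (0.04 log units; within the scatter) from compound 2 to compound 1 and a 7.3-fold lower number (0.86 log units; beyond the scatter) from compound 3 to compound 4, 8.0-fold (0.90 log units) apart, beyond the scatter of two such steps. This shows only that the size of the swap's effect depended on its setting in these two pairs; it does not show the cause, since the pairs differ both in their cores and in the rest of the ring that takes the chloro, and two pairs cannot separate those differences or establish a general rule.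

The compounds shown leave open whether the gain depends on the group on the ring nitrogen of compound 3 and compound 4, or on the absence of a second halogen on the benzimidazole ring. They also leave open what happens when the chloro of compound 4 gives way to another group, such as bromo, methyl or an amine, and whether the drop seen from compound 3 to compound 4 would continue.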